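The source may hold more compounds than are shown below. What is called first, only, known or untested is meant among the compounds shown, and "the series" means these compounds.

Of the compounds shown here, three built on one shared core have been tested in a functional assay on cells for antagonist activity at prostaglandin D2 receptor 2 (Homo sapiens), read by flow cytometry, with a stated time of 10 min; on this read-out higher numbers stand for weaker inhibition and lower numbers for stronger inhibition. Compound 1 `CN(C)S(=O)(=O)c1ccc(F)c(C#Cc2cc(Cl)ccc2OCC(=O)O)c1` gives 23 nM, compound 2 `CC(C)S(=O)(=O)c1ccc(Cl)c(C#Cc2cc(Cl)ccc2OCC(=O)O)c1` gives 67 nM, and compound 3 `COCCNS(=O)(=O)c1ccc(C)c(C#Cc2cc(Cl)ccc2OCC(=O)O)c1` gives 88 nM. On these numbers compound 3 sits highest of the three, yet its gap to compound 2 is within the usual scatter of such measurements, so the two cannot really be separated, while its gap to compound 1 lies beyond the scatter.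

Compound 4 `Cc1ccc(S(C)(=O)=O)cc1C#Cc1cc(Cl)ccc1OCC(=O)O` has not yet been measured in this assay. It differs from compound 3 in one place: methyl in place of (2-methoxyethyl)amino on a sulfonyl sulfur. The group that leaves is larger and carries one hydrogen-bond donor and one acceptor; the group that enters is a single methyl with neither. For the measured compounds named here, no pair among the measured compounds differs in just this way, so no measured step can guide the expectation directly. Across the three measured compounds, changes around the sulfonyl group and its neighbouring substituent move the numbers only modestly, so the step from compound 3 to compound 4 is expected to be small, if anything downward, and probably within the scatter, giving a 1.6-fold lower number from compound 3 to compound 4 (0.20 log units; within the scatter). Compound 4 is therefore estimated at 55 nM, with a likely range from 18 nM to 160 nM.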

Compound 4, half-maximal inhibitory concentration: 64 nM
The estimate for compound 4 lay 1.2-fold (0.07 log units) below the measured number; the measured number falls inside the stated range.
By their numbers in this assay, from the lowest: compound 1; then compounds 4, 2 and 3 (each within the scatter of the next).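

In this assay, for the compounds shown here, putting methyl in place of (2-methoxyethyl)amino on a sulfonyl sulfur gives a 1.4-fold lower number from compound 3 to compound 4 (0.14 log units; within the scatter), the first comparison in this set in which only this group changes. The group that leaves is larger and carries a hydrogen-bond donor and an acceptor, while the methyl that enters has neither, yet compound 3 and compound 4 cannot be separated in this assay, so for this pair neither the larger chain nor its donor and acceptor makes a difference that the read-out can resolve. Nothing measured here explains why the two compounds read alike.

This single pair does not show whether other groups on the same sulfur, such as a plain amino group, a dimethylamino group with the rest of compound 3 unchanged, or a longer carbon chain such as butyl, would also leave the number in place. Compound 1 differs from both compound 3 and compound 4 in more than one place, so which of its differences accounts for its separate standing remains open.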